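A few compounds are considered here, and "the series" means these few. Any claim that something is new, unique, unknown or untested is made for them only; others in the source may bear on it.

Measured so far in a physicochemical assay for lipophilicity; on this read-out lower numbers stand for lower lipophilicity and higher numbers for higher lipophilicity:
- Compound 1 `CCCCNC(=O)c1ccc(S(N)(=O)=O)cc1`: 1.05
- Compound 2 `CCCCCCNC(=O)c1ccc(S(N)(=O)=O)cc1`: 2.05

Of the two measured compounds, compound 2 stands higher at 2.05. The next compound is compound 3 `CCCCCCCNC(=O)c1ccc(S(N)(=O)=O)cc1`, and the change is methyl in place of hydrogen on a saturated chain carbon, six bonds along the chain from an amide-type nitrogen.

Among the measured compounds shown here, only one measured step bears on this: a number 1.00 log units higher from compound 1 to compound 2 (beyond the scatter). It is a modest step beyond the scatter, for ethyl in place of hydrogen on a saturated chain carbon, four bonds along the chain from an amide-type nitrogen. With methyl entering on the same chain, a rise in this assay is expected again, though a smaller one. A single step is thin support for this.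

The expected change is a number 0.50 log units higher from compound 2 to compound 3 (beyond the scatter). For compound 3 the estimated value is 2.55, with an expected range of 2.3 to 2.85.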

Compound 3, partition coefficient: 2.57
Beside the measured number, compound 3's estimate is 0.02 log units below it, and the stated range covers the measured number.
By their numbers in this assay, from the lowest: compound 1; then compound 2; then compound 3.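

In this assay, a single methyl at this place, six bonds along the chain from an amide-type nitrogen, still moves the number beyond the scatter, with a number 0.52 log units higher from compound 2 to compound 3 (beyond the scatter). Read as one change, propyl in place of hydrogen four bonds along the chain gives a number 1.52 log units higher from compound 1 to compound 3 (beyond the scatter), so the number rises with each extension across the three compounds and none goes against this order. No measurement here accounts for the rise.

From the compounds shown here alone, whether the rise continues with a longer chain such as octyl, or flattens out, remains open. Also open, going by these compounds, is how a branched chain, or an amine or a carboxylic acid on the chain, would compare with the plain chains at this place.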